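Phenoxy to fluoro on the aryloxy ketone series

A few compounds are considered here, and "the series" means these few. Any claim that something is new, unique, unknown or untested is made for them only; others in the source may bear on it.

Measured in a functional assay on Jurkat cells (Homo sapiens); on this read-out higher numbers stand for weaker inhibition and lower numbers for stronger inhibition:
- compound 1 `CC(C)[C@H](NC(=O)COc1cccc2ccccc12)C(=O)N[C@@H](CC(=O)O)C(=O)COc1cccc2ccccc12`: > 100000 nM (a limit)
- compound 2 `CC(C)[C@H](NC(=O)COc1cccc2ccccc12)C(=O)N[C@@H](CC(=O)O)C(=O)COc1ccc(C#N)cc1`: > 100000 nM (a limit)
- compound 3 `CC(C)[C@H](NC(=O)COc1cccc2ccccc12)C(=O)N[C@@H](CC(=O)O)C(=O)COc1ccc(Oc2ccccc2)cc1`: 12700 nM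

Compound 3 alone has a number, 12700 nM. The other two compounds stand at the limit of > 100000 nM in this assay, at which 2 of the 3 values shown sit.

Compound 4 `CC(C)[C@H](NC(=O)COc1cccc2ccccc12)C(=O)N[C@@H](CC(=O)O)C(=O)COc1ccc(F)cc1` is the next compound to read. The change is fluoro in place of phenoxy on an aromatic carbon, para to a large group.

The closest measured step is an at least 7.8-fold lower number from compound 2 to compound 3 (0.89 log units; beyond the scatter), which put phenoxy in place of cyano on an aromatic carbon. The step that the two limits leave unreadable from compound 1 to compound 2 gives no size to work with. Compound 4, like compound 2, has no phenoxy, so a move back towards the limit is expected in this assay, beyond the scatter and towards a higher number. The expected change is a 7.1-fold higher number from compound 3 to compound 4 (0.85 log units; beyond the scatter). A reading that reports only a limit is about as likely as a number. For compound 4 the estimate is 90000 nM, with an expected range of 30000 nM to 250000 nM.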

Compound 4, half-maximal inhibitory concentration: > 100000 nM
Compound 4 gave a limit, no number; the forecaster's own chance of this, stated with the estimate: 50%; middle value at least 1.1-fold (0.04 log units) away from the limit.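

In this assay, fluoro in place of phenoxy on this aromatic carbon, para to a large group, gives an at least 7.8-fold higher number from compound 3 to compound 4 (0.89 log units; beyond the scatter). Compound 4 gives > 100000 nM, which is a limit and not a number. Fluoro now joins cyano in reading only as a limit at this carbon, so among these para groups phenoxy alone gives a number, and the series reads almost entirely as a limit: the limit of > 100000 nM in this assay, at which 3 of the 4 values shown sit.

The steps among compound 1, compound 2 and compound 4 cannot be read, so the compounds shown give no order among them. Open, going by these compounds, is whether the number in compound 3 needs the whole phenoxy group, or whether a methoxy, a benzyloxy or an amine on the same carbon would also give a number in this assay.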